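This account rests on a few compounds, and the source may have more. Where it says the series, first, only, none or still open, it means among the compounds named here.

Measured compounds:
- compound 1, `O=C(NC[C@H](NS(=O)(=O)c1ccccc1)C(=O)O)c1ccc(N2CCC(NC3=NCCCN3)CC2)c(O)c1`, in a functional assay on a cell-free system (Platelet, plasma, Homo sapiens) for inhibition (on this read-out lower numbers stand for stronger inhibition and higher numbers for weaker inhibition), compound 1 gives 170 nM
- compound 2, `O=C(NC[C@H](NS(=O)(=O)c1ccccc1)C(=O)O)c1ccc(N2CCC[C@H](NC3=NCCCN3)C2)cc1F`, in this assay compound 2 gives 290 nM
- compound 3, `O=C(NC[C@H](NS(=O)(=O)c1cccs1)C(=O)O)c1ccc(N2CCC[C@H](NC3=NCCCN3)C2)cc1`, in this assay compound 3 gives 99 nM

On these three numbers compound 1 stands second highest. Its nearest neighbour is compound 2, whose number is higher, and the furthest is compound 3, whose number is lower; both gaps fall within the usual scatter, so the three compounds cannot be told apart on potency with the data in hand.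

The next compound to be tested is compound 4, `O=C(NC[C@H](NS(=O)(=O)c1ccccc1)C(=O)O)c1ccc(N2CCC(NC3=NCCCN3)CC2)c(F)c1`. It differs from compound 1 by fluoro in place of hydroxy on an aromatic carbon, on an aromatic carbon of a six-membered aromatic ring of carbon only, ortho to a large group and meta to a large group. Going by the values given here, no pair of measured compounds isolates this change, so there is no directly comparable step. Compound 2 carries a fluoro on the same ring with a different saturated ring, and its number in this assay sits within the scatter of compound 1. On that basis the step is expected to be a 1.4-fold higher number from compound 1 to compound 4 (0.15 log units; within the scatter), which would leave the number close to where compound 1 lies. Compound 4 is estimated at 240 nM in this assay, with a range of 90 nM to 650 nM.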

Compound 4, half-maximal inhibitory concentration: 37 nM
Compound 4: the middle estimate sits 6.5-fold (0.81 log units) above what was measured, and the stated range ends above it.
By their numbers in this assay, from the lowest: compound 4; then compounds 3, 1 and 2 (each within the scatter of the next, the first and the last beyond it).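

In this assay, going by these compounds alone, fluoro in place of hydroxy on an aromatic carbon, ortho to a large group and meta to a large group, gives a 4.6-fold lower number from compound 1 to compound 4 (0.66 log units; beyond the scatter), the first step that can be read and one beyond the scatter. This position therefore responds to the substituent, and hydroxy is not required for inhibition on the core of compound 1, since compound 4 lacks it and gives the lower number. No measurement on hand accounts for the step.

As far as these compounds go, whether the step reflects the arrival of fluoro or the loss of hydroxy stays open, and hydrogen, chloro or methoxy at this position would help separate the two. From the compounds shown here alone, whether it carries over to the cores of compound 2 and compound 3 also stays open, as each differs from compound 4 in more than one place.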